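Isobutyl to sec-Butyl on Three Cell-Growth Inhibitors

The source may hold more compounds than are shown below. What is called first, only, known or untested is meant among the compounds shown, and "the series" means these compounds.

Compound 3 `COc1cc(/C=C/C(=O)/C=C(/C=C/c2ccc(O)c(OC)c2)NCC(C)C)ccc1O` carries an isobutyl group on its amine nitrogen. In a functional assay on CHO-K1 cells (Cricetulus griseus) for inhibition, read by sulforhodamine B assay, with a stated time of 72 h (a higher number here means a weaker inhibitor, a lower number a stronger inhibitor), compound 3 gives > 25000 nM, which is a limit of the assay rather than a number. Compound 1 `CCC(C)NC(=C\C(=O)/C=C/c1ccc(O)c(OC)c1)/C=C/c1ccc(O)c(OC)c1` differs from it by sec-butyl in place of isobutyl on an amine nitrogen. In this assay compound 1 gives > 25000 nM, again a limit. The step that the two limits leave unreadable from compound 3 to compound 1 cannot be sized because of the limit of > 25000 nM in this assay, at which 3 of the 3 values shown sit. Compound 2 `COc1cc(/C=C/C(=O)/C=C(/C=C/c2ccc(OC(C)=O)c(OC)c2)NCC(C)C)ccc1OC(C)=O` has another core; the difference between the two cores is not broken down here. In this assay compound 2 gives > 25000 nM, also a limit. Compound 4 `CCC(C)NC(=C\C(=O)/C=C/c1ccc(OC(C)=O)c(OC)c1)/C=C/c1ccc(OC(C)=O)c(OC)c1` is compound 2 after the same change, (sec-butyl in place of isobutyl on an amine nitrogen), at the same place. Given a step that the two limits leave unreadable from compound 3 to compound 1, the change is expected to move compound 4 by a step that the limit leaves unreadable from compound 2 to compound 4. Compound 4 is estimated to give about 30000 nM in this assay.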

Compound 4, half-maximal inhibitory concentration: > 25000 nM
Compound 4 ended at the assay's limit; the forecaster's own chance of this, stated with the estimate: 85%; the middle value does not contradict the limit.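

No new step can be read from compound 2 to compound 4, because both values are limits: the limit of > 25000 nM in this assay, at which 4 of the 4 values shown sit. The compounds shown leave open whether isobutyl and sec-butyl differ at all in this assay.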